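From compound 1 to compound 4: losing the selenium chain

A few compounds are considered here, and "the series" means these few. Any claim that something is new, unique, unknown or untested is made for them only; others in the source may bear on it.

compound 1 `COc1ccc(N(C)c2nc(C)nc3ccccc23)cc1C(=O)NCC[Se]C#N` gives 187 nM
compound 2 `C[Se]c1ccc(N(C)c2nc(C)nc3ccccc23)cc1Cl` gives 2 nM
compound 3 `COc1ccc(N(C)c2nc(C)nc3ccccc23)cc1C(=O)OCCCCCC[Se]C#N` gives 488 nM

In a functional assay on A549 cells (Homo sapiens) for inhibition, read by MTT assay, with a stated time of 48 h (a higher number here means a weaker inhibitor, a lower number a stronger inhibitor), compound 1 at 187 nM holds the second highest of the three numbers, far above compound 2 and under compound 3. Compound 4 `COc1ccc(N(C)c2nc(C)nc3ccccc23)cc1OCCN` is still unmeasured, and its change from compound 1 is a group of 4 heavy atoms (2 carbon, 1 nitrogen, 1 oxygen; no ring) in place of a group of 8 heavy atoms (4 carbon, 2 nitrogen, 1 oxygen, 1 selenium; no ring), on an aromatic carbon with 2-aminoethoxy as the entering group, ortho to a methoxy group.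

Within the data shown here, only one measured step bears directly on this: a 2.6-fold higher number from compound 1 to compound 3 (0.42 log units; beyond the scatter) is a modest rise on moving to a larger selenium-bearing group. Among the measured compounds shown here, compound 4 goes the other way in size and carries no selenium, but no measured compound holds its group, so this is weak guidance. Compound 2 differs in more than one place, yet at 2 nM it shows how low numbers on the shared core can reach.

The estimated step is a 4.7-fold lower number from compound 1 to compound 4 (0.67 log units; beyond the scatter) in the direction of a lower number. For compound 4 the expected value is 40 nM with an estimated range of 6 nM to 250 nM in this assay as the working figure.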

Compound 4, half-maximal inhibitory concentration: 122 nM
Compound 4: middle estimate off by 3.1-fold (0.48 log units), on the low side, within the range that was stated.
By their numbers in this assay, from the lowest: compound 2; then compounds 4 and 1 (each within the scatter of the next); then compound 3.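

In this assay the step of a 1.5-fold lower number from compound 1 to compound 4 (0.19 log units; within the scatter) shows that, at this aromatic carbon ortho to a methoxy group, 2-aminoethoxy can take the place of the selenium-bearing group with no difference beyond the scatter. Within this pair, then, a number in this range does not depend on selenium, and the much smaller entering group carries the same count of hydrogen-bond donors and acceptors as the group that leaves. Nothing available explains why the two compounds stand so close.

Still open, from the compounds shown here alone, is whether a longer chain such as 3-aminopropoxy, or 2-hydroxyethoxy with a hydroxyl in place of the amine, would keep this level at the same carbon. Also open is which of the differences separating compound 2 from this pair accounts for its far lower number.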